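Halogen swap on one aryl ring of a diarylthiourea

The source may hold more compounds than are shown below. What is called first, only, known or untested is meant among the compounds shown, and "the series" means these compounds.

Compound 3 `Fc1ccc(NC(=S)Nc2cccc(C(F)(F)F)c2)cc1` is one of three thioureas characterised in an ADME assay on Vero 76 cells (Chlorocebus sabaeus) for cytotoxicity, read by crystal violet staining, with a stated time of 96 h (on this read-out higher numbers stand for lower toxicity in this test and lower numbers for higher toxicity in this test), where compound 3 gives 40000 nM. It has the second highest of the three numbers: compound 1 `Fc1ccccc1NC(=S)Nc1cccc(C(F)(F)F)c1` gives 64000 nM, and compound 2 `FC(F)(F)c1cccc(NC(=S)Nc2ccc(Cl)cc2)c1` gives 11000 nM. The step of a 1.6-fold lower number from compound 1 to compound 3 (0.20 log units; within the scatter) is small, whereas a 3.6-fold higher number from compound 2 to compound 3 (0.56 log units; beyond the scatter) and a 5.8-fold lower number from compound 1 to compound 2 (0.76 log units; beyond the scatter) are modest and clear.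

Compound 4 `FC(F)(F)c1cccc(NC(=S)Nc2ccccc2Br)c1` differs from compound 3 in a single place: 2-bromophenyl in place of 4-fluorophenyl on an amide-type nitrogen. For the measured compounds named here, two measured steps bear on this. Moving the substituent from one ring position to another, as from compound 1 to compound 3, changed little, while exchanging fluoro for chloro, as from compound 2 to compound 3, moved the number by a 3.6-fold higher number from compound 2 to compound 3 (0.56 log units; beyond the scatter). Introducing a heavier halogen is therefore expected to lower the number in this assay, by a modest amount, because compound 2 gives 11000 nM. Compound 4 is thus expected to give 20000 nM in this assay, within a range of 8000 nM to 50000 nM, an expected step of a 2.0-fold lower number from compound 3 to compound 4 (0.30 log units; within the scatter).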

Compound 4, half-maximal cytotoxic concentration: 50000 nM
Compound 4: middle estimate off by 2.5-fold (0.40 log units), on the low side; low and high end bracket the measured number.
By their numbers in this assay, from the lowest: compound 2; then compounds 3, 4 and 1 (each within the scatter of the next).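

In this assay, the 2-bromophenyl group on the amide-type nitrogen stays level with both fluorophenyl partners, with a 1.3-fold higher number from compound 3 to compound 4 (0.10 log units; within the scatter) and a 1.3-fold lower number from compound 1 to compound 4 (0.11 log units; within the scatter), so bromo in this group does not bring the number down. Only the 4-chlorophenyl group of compound 2 stands apart, with a 4.5-fold higher number from compound 2 to compound 4 (0.66 log units; beyond the scatter), and compound 4 therefore goes against any reading in which a heavier halogen on this ring lowers the number. No measured evidence is at hand to explain this difference.

The compounds shown leave open whether the lower number of compound 2 goes with chloro itself or with its place on the ring, a question that a 2-chlorophenyl or a 4-bromophenyl group would separate. As far as these compounds go, how an amine or a methoxy group on this ring would read in this assay also stays open.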